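From a Carboxy Ring to a Methoxyphenyl

The source may report more compounds than this note shows. Statements on the series, on what has been measured and on what is new or still open speak of the compounds shown alone.

Measured compounds:
- Compound 1, `COc1ccc(C(=O)O)cc1OC[C@H](C)COc1ccc(C(=O)CC(C)(C)C)c(O)c1C`: in an assay for positive allosteric modulation of metabotropic glutamate receptor 2 (Rattus norvegicus) (on this read-out higher numbers stand for an effect only at larger amounts of compound and lower numbers for an effect already at smaller amounts), compound 1 gives 63 nM.
- Compound 2, `Cc1c(OC[C@@H](C)COc2ccc(C(=O)O)cc2F)ccc(C(=O)CC(C)(C)C)c1O`: in this assay compound 2 gives 222 nM.

Compound 2 has the higher of the two numbers in this assay; the nearest, compound 1, sits clearly lower, by more than the usual scatter, so compound 2 needs more material for its effect than compound 1 does.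

Compound 3, `COc1ccccc1OC[C@H](C)COc1ccc(C(=O)CC(C)(C)C)c(O)c1C`, has not been measured. It differs from compound 2 in one place: 2-methoxyphenyl in place of 4-carboxy-2-fluorophenyl on an oxygen on a saturated carbon. With this change the hydrogen-bond donor of the leaving group is gone, and the fluorine with it, while a 2-methoxyphenyl enters on the same oxygen.

Within the data shown here, no measured pair shows what such a change does here, so only an expectation can be given. Both measured compounds carry the 4-carboxy group, and compound 2 with 222 nM already stands at the weaker end. Compound 3 is expected to move further in that direction, with a step of a 3.2-fold higher number from compound 2 to compound 3 (0.50 log units; beyond the scatter) in this assay. The estimate for compound 3 is 700 nM, within a range from 150 nM to 3000 nM.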

Compound 3, half-maximal effective concentration: "not active" (no number reported)
Compound 3: no number reported, and the estimate cannot be compared.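

Among these compounds, compound 3 is reported as not active in this assay and carries no number, so no step from compound 2 to compound 3 can be read. Nothing shown here accounts for this result. The compounds shown leave open which part of the change matters: the departing 4-carboxy-2-fluorophenyl or the entering 2-methoxyphenyl.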